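Phenyl for methyl on the piperazine of compound 1

The source may hold more compounds than are shown below. What is called first, only, known or untested is meant among the compounds shown, and "the series" means these compounds.

Compound 1 `CN1CCN(C(=O)c2c(NC(=O)NS(=O)(=O)c3ccccc3)sc3c2CCCCC3)CC1`: 49200 nM
Compound 2 `O=C(Nc1sc2c(c1C(=O)NNc1ccc(Cl)cc1)CCCCC2)NS(=O)(=O)c1ccccc1`: 5900 nM

In a functional assay on cells (Cancer cell lines, Homo sapiens) for inhibition, with a stated time of 48 h (a lower number here means a stronger inhibitor of growth, a higher number a weaker inhibitor of growth), compound 1 gives the higher of the two numbers; compound 2 sits an 8.3-fold lower number from compound 1 to compound 2 (0.92 log units; beyond the scatter) below it. Compound 3 `O=C(Nc1sc2c(c1C(=O)N1CCN(c3ccccc3)CC1)CCCCC2)NS(=O)(=O)c1ccccc1` differs from compound 1 by phenyl in place of methyl on an amine nitrogen in a ring. Among the compounds with values here, the only measured step, from compound 1 to compound 2, changes the whole group on the carbonyl carbon, not the ring nitrogen, so it does not test this change. Compound 3 is therefore expected to move a 2.5-fold lower number from compound 1 to compound 3 (0.39 log units; beyond the scatter), with wide uncertainty. Compound 3 is estimated at 20000 nM, in a range from 6000 nM to 60000 nM.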

Compound 3, concentration for 50% growth inhibition: 58200 nM
Beside the measured number, compound 3's estimate is 2.9-fold (0.46 log units) below it; the measured number falls inside the stated range.
By their numbers in this assay, from the lowest: compound 2; then compounds 1 and 3 (each within the scatter of the next).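

In this assay, phenyl in place of methyl on the amine nitrogen of the piperazine does not separate the two compounds (a 1.2-fold higher number from compound 1 to compound 3 (0.07 log units; within the scatter)). This larger group therefore does not bring the piperazine amide to the level of compound 2, and the gap to the ((4-chlorophenyl)amino)amino group remains (a 9.9-fold higher number from compound 2 to compound 3 (0.99 log units; beyond the scatter)). No evidence on hand accounts for these results. As far as these compounds go, it remains open whether a 4-chlorophenyl group or an acetyl group on that ring nitrogen would do otherwise, and whether a bare amine hydrogen there would change the number.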